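Methoxy in place of nitro: compound 3 from compound 1

This account rests on a few compounds, and the source may have more. Where it says the series, first, only, none or still open, it means among the compounds named here.

Compound 1 `CC1(C)N=C(N)N=C(N)N1c1cccc(CNC(=O)Nc2cccc([N+](=O)[O-])c2)c1` gives 8.1 in an assay on isolated protein for inhibition of Dihydrofolate reductase (Mus musculus) (on this read-out lower numbers stand for lower potency and higher numbers for higher potency (the scale is a negative logarithm)), the highest of the two numbers in hand. Compound 2 `CC1(C)N=C(N)N=C(N)N1c1ccc(OCc2cccc(C(=O)Nc3cccc(S(=O)(=O)F)c3)c2)c(Cl)c1` gives 7.24 in this assay, a number lower than that of compound 1 by more than the scatter. Compound 3 `COc1cccc(NC(=O)NCc2cccc(N3C(N)=NC(N)=NC3(C)C)c2)c1` differs from compound 1 in one place: methoxy in place of nitro on an aromatic carbon. Going by the values given here, no step between measured compounds bears on this exchange, so the expectation rests on compound 1 alone. A small loss in this assay is expected, a number 0.30 log units lower from compound 1 to compound 3 (within the scatter), though a result within the scatter would not surprise. Compound 3 is estimated at 7.8, between 7.2 and 8.4.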

Compound 3, logarithm of the reciprocal of the active concentration, log(1/C): 8.02
For compound 3 the middle estimate is 0.22 log units below the measured one, within the range that was stated.
By their numbers in this assay, from the lowest: compound 2; then compounds 3 and 1 (each within the scatter of the next).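

In this assay, methoxy in place of nitro on this aromatic carbon gives a number 0.08 log units lower from compound 1 to compound 3 (within the scatter). The nitro group is therefore not needed to hold the number here, and the 3-methoxyphenyl urea reads alike with the 3-nitrophenyl one, although the entering group has fewer heavy atoms and hydrogen-bond acceptors. No measurement shown accounts for this match.

On these data alone, whether an amine or a carboxylic acid on the same carbon would also read alike remains open. So does the reach of this position for a longer chain, such as butoxy.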